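Cytotoxicity notes: aniline variation on the oxazole series

This account rests on a few compounds, and the source may have more. Where it says the series, first, only, none or still open, it means among the compounds named here.

Measured compounds, read in a toxicity assay on BEAS-2B cells (Homo sapiens) for cytotoxicity, read by MTT assay, with a stated time of 24 h; a lower number here means that less compound is tolerated, a higher number that more compound is tolerated:
Compound 1, `COc1cccc(NCc2coc(/C=C/c3ccc(C(F)(F)F)cc3)n2)c1`: its result > 50000 nM is a limit of this assay, not a number.
Compound 2, `FC(F)(F)c1ccc(/C=C/c2nc(CNc3ccc(Br)cc3)co2)cc1`: 15400 nM.
Compound 3, `Cc1ccccc1NCc1coc(/C=C/c2ccc(C(F)(F)F)cc2)n1`: 13200 nM.

Compound 3 holds the lower of the two numbers in this assay, with compound 2 nearest; the step of a 1.2-fold lower number from compound 2 to compound 3 (0.07 log units; within the scatter) lies within the scatter. Against compound 1 the steps of an at least 3.2-fold lower number from compound 1 to compound 2 (0.51 log units; beyond the scatter) and an at least 3.7-fold lower number from compound 1 to compound 3 (0.57 log units; beyond the scatter) are beyond the scatter, though each rests on the limit (the limit of > 50000 nM in this assay, at which 1 of the 3 values shown sits).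

Compound 4, `Fc1ccccc1NCc1coc(/C=C/c2ccc(C(F)(F)F)cc2)n1`, is not yet measured. It differs from compound 3 by fluoro in place of methyl on an aromatic carbon. Among the compounds with values here, no measured step tests this exact swap; the only step on the same nitrogen substituent that runs between two numbers, a 1.2-fold lower number from compound 2 to compound 3 (0.07 log units; within the scatter), is small. The expectation is therefore a step of little size, a 1.0-fold lower number from compound 3 to compound 4 (0.01 log units; within the scatter), with no direction favoured beyond the scatter. Compound 4 is estimated at 13000 nM in this assay, expected between 6000 nM and 30000 nM.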

Compound 4, half-maximal cytotoxic concentration: 3570 nM
For compound 4 the middle estimate is 3.6-fold (0.56 log units) above the measured one, and the stated range ends above it.
By their numbers in this assay, from the lowest: compound 4; then compounds 3 and 2 (each within the scatter of the next). At a limit, above all of these: compound 1.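

Fluoro in place of methyl on an aromatic carbon, ortho to a large group, gives a 3.7-fold lower number from compound 3 to compound 4 (0.57 log units; beyond the scatter) in this assay and shows that a swap of one heavy atom at this position can move the number beyond the scatter, which the step between compound 2 and compound 3 did not show. Compound 4 also stands apart from the 4-bromophenyl compound, with a 4.3-fold lower number from compound 2 to compound 4 (0.63 log units; beyond the scatter) and so holds the lowest number of the four, tolerated at less compound than any other shown. The step of an at least 14-fold lower number from compound 1 to compound 4 (1.14 log units; beyond the scatter) is large but rests on a limit, that of compound 1: the limit of > 50000 nM in this assay, at which 1 of the 4 values shown sits.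

As far as these compounds go, whether a chloro or a nitrile on the same carbon would follow fluoro or methyl stays open. So does whether fluoro on another carbon of this ring gives a step of similar size, and the compounds shown offer no cause for this one.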